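The source may report more compounds than this note shows. Statements on the series, on what has been measured and on what is new or still open speak of the compounds shown alone.

Compound 1 `COc1ccc(C)cc1N1C(=O)CSC1c1cccc(C(=O)NCCCCc2ccccc2)c1` is the weaker of the two compounds measured in a functional assay on HOS-TE85 cells (Homo sapiens) for inhibition, read by CCK-8 assay, with a stated time of 72 h (a lower number here means a stronger inhibitor, a higher number a weaker inhibitor), where compound 1 gives 300 nM. Compound 2 `O=C(NCCCCn1cccn1)c1cccc(C2SCC(=O)N2c2ccccn2)c1` gives 60.3 nM, and the gap between the two lies beyond the scatter; as compound 2 differs from compound 1 in more than one place, the numbers alone do not assign it to any single change. Compound 3 `O=C(NCCCCc1ccccc1)c1cccc(C2SCC(=O)N2c2ccc(-c3ccccc3)cc2)c1` arises from compound 1 by one change: 4-phenylphenyl in place of 2-methoxy-5-methylphenyl on an amide-type nitrogen in a ring. For the measured compounds named here, no measured pair isolates this change, so a step of a 1.4-fold lower number from compound 1 to compound 3 (0.13 log units; within the scatter) is expected, none beyond the scatter. Compound 3 is estimated at 220 nM, with a range of 60 nM to 800 nM.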

Compound 3, half-maximal inhibitory concentration: > 1000 nM
Compound 3: a limit, no number; the forecaster's own chance of this, stated with the estimate: 5%; at least 4.5-fold (0.65 log units) between middle value and limit.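

For the compounds shown here, at the amide-type nitrogen in the ring, 4-phenylphenyl in place of 2-methoxy-5-methylphenyl gives an at least 3.3-fold higher number from compound 1 to compound 3 (0.52 log units; beyond the scatter), the first step that isolates this position and shows that the group there matters in this assay. The value of compound 3, > 1000 nM, is a limit of the assay and not a number. The step therefore has a floor but no measured size: the limit of > 1000 nM in this assay, at which 1 of the 3 values shown sits.

These compounds cannot separate the added second phenyl ring from the missing methoxy and methyl groups. On these data alone, how plain phenyl or 2-methoxyphenyl on this nitrogen would read in this assay remains open.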